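Oxazolone ureas against acid ceramidase: a ring-swap step

A few compounds are considered here, and "the series" means these few. Any claim that something is new, unique, unknown or untested is made for them only; others in the source may bear on it.

Of the compounds shown here, three have numbers so far. Compound 1 `CN1CCN(c2ccc3c(c2)oc(=O)n3C(=O)NCCCCc2ccccc2)CC1=O` gives 92 nM in an assay on HEK293 cells for inhibition of acid ceramidase (Homo sapiens), read by fluorescence, with stated times of 10 min and 3 h; a lower number here means a stronger inhibitor, a higher number a weaker inhibitor. Compound 2 `CCN1CCC(c2ccc3c(c2)oc(=O)n3C(=O)NCCCCc2ccccc2)CC1` gives 92 nM in this assay, and compound 3 `COCCCNC(=O)n1c(=O)oc2cc(-c3ccc(F)cc3)ccc21` gives 2600 nM in this assay. Within the data shown here, the one single-point step measured so far, no change at the digits printed from compound 1 to compound 2 (within the scatter), showed no movement. Compound 2 therefore stands level with compound 1 at the digits shown, the two together at the low end of the three numbers, while compound 3 lies far above both.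

Compound 4 `CN1CCN(c2ccc3c(c2)oc(=O)n3C(=O)NCCCCc2ccccc2)C(=O)C1` is the next point. Its difference from compound 2 is 4-methyl-2-oxopiperazin-1-yl in place of 1-ethylpiperidin-4-yl on an aromatic carbon. Among the measured compounds shown here, the entering group is a near relative of the 4-methyl-3-oxopiperazin-1-yl of compound 1, and the only step that bears on it, no change at the digits printed from compound 1 to compound 2 (within the scatter), was flat. On that basis the step of a 1.1-fold higher number from compound 2 to compound 4 (0.04 log units; within the scatter) is expected to stay within the scatter, with no direction favoured. Compound 4 is estimated at 100 nM in this assay, with a range of 40 nM to 260 nM.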

Compound 4, half-maximal inhibitory concentration in the acid ceramidase assay: 52 nM
Beside the measured number, compound 4's estimate is 1.9-fold (0.28 log units) above it; the measured number falls inside the stated range.
By their numbers in the acid ceramidase assay, from the lowest: compounds 4, 1 and 2 (each within the scatter of the next); then compound 3.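

In the acid ceramidase assay this aromatic carbon accepts the 4-methyl-2-oxopiperazin-1-yl with no step beyond the scatter, whether the group it replaces is the 1-ethylpiperidin-4-yl, a 1.8-fold lower number from compound 2 to compound 4 (0.25 log units; within the scatter), or the 4-methyl-3-oxopiperazin-1-yl, a 1.8-fold lower number from compound 1 to compound 4 (0.25 log units; within the scatter). In a physicochemical assay for solubility, read by HPLC, in phosphate buffer, measured as kinetic solubility, with a stated time of 1 h, at pH 7.4, tested at 250 uM (a lower number here means a less soluble compound, a higher number a more soluble compound), however, compound 2 gives 198000 nM and compound 4 gives 20000 nM. The two groups, indistinguishable on the enzyme read-out, are therefore separated by solubility: the measured solubility of compound 2, 198000 nM, and of compound 4, 20000 nM, a 9.9-fold lower number (1.00 log units; beyond the scatter)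

Still open, on these data alone, is where a morpholine, or a piperidine carrying a carboxylic acid, would fall at this aromatic carbon in the acid ceramidase assay and in the physicochemical assay. Also open, as far as these compounds go, is whether any group here can hold the number of compound 2 in the acid ceramidase assay and its solubility together.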